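The compounds below may be only part of what the source reports. "The series", "measured", "known", "first", "only" and "open" are said of these compounds alone.

Measured compounds:
Compound 1, `c1ccc(-c2cn3ccnc3c(-c3ccc4ncn(C5CCCCC5)c4c3)n2)cc1`, gives 39.6% in a functional assay on LOX IMVI cells (Homo sapiens) for inhibition, read by sulforhodamine B assay, with a stated time of 48 h, tested at 10 uM; on this read-out lower numbers stand for less inhibition and higher numbers for more inhibition at the one concentration tested (going by the name of the read-out).
Compound 2, `COc1ccc(-c2cn3ccnc3c(-c3ccc4ncn(C5CCCCC5)c4c3)n2)cc1`, gives 69.6%.
Compound 3, `Fc1ccc(-c2cn3ccnc3c(-c3ccc4ncn(C5CCCCC5)c4c3)n2)cc1`, gives 3.5%.

Compound 3 stands lowest of the three numbers in this assay: compound 1 is nearest, the step being a number 36.1 percentage points lower from compound 1 to compound 3 (beyond the scatter), and compound 2 is furthest, the step being a number 66.1 percentage points lower from compound 2 to compound 3 (beyond the scatter). Both steps lie beyond the scatter, so the group on this aromatic carbon clearly moves the read-out within this small set.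

Compound 4, `c1csc(-c2cn3ccnc3c(-c3ccc4ncn(C5CCCCC5)c4c3)n2)c1`, is not yet measured. It differs from compound 3 by thiophen-2-yl in place of 4-fluorophenyl on an aromatic carbon. For the measured compounds named here, no measured step replaces one ring with a ring of another kind at this position; the steps that bear on it, a number 36.1 percentage points lower from compound 1 to compound 3 (beyond the scatter) and a number 66.1 percentage points lower from compound 2 to compound 3 (beyond the scatter), only show that the read-out has ranged widely as the group at this place changes, and that compound 3 is at the floor of that range. From the floor, a change of this size is more likely to raise than to lower the number, but its direction is not fixed by any measured pair.

Compound 4 is therefore expected to give about 30%, within 0% to 65%, an expected step of a number 26.5 percentage points higher from compound 3 to compound 4 (beyond the scatter).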

Compound 4, a percentage reported as inhibition, at one concentration (the size of the read-out at that concentration, not a potency): 1.07%
Compound 4: the middle estimate sits 28.9 percentage points above what was measured, and the stated range covers the measured number.
By their numbers in this assay, from the lowest: compounds 4 and 3 (each within the scatter of the next); then compound 1; then compound 2.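

For the compounds shown here, the swap of compound 3 to compound 4 is the first in this set to put a ring of another kind at this place, and in this assay it gives a number 2.4 percentage points lower from compound 3 to compound 4 (within the scatter), so a five-membered aromatic ring with one hetero atom and a 4-fluorophenyl group cannot be told apart here. Set against the other two groups, thiophen-2-yl falls well short, with a number 38.5 percentage points lower from compound 1 to compound 4 (beyond the scatter) and a number 68.5 percentage points lower from compound 2 to compound 4 (beyond the scatter), so among these four compounds the clear inhibition belongs only to the phenyl of compound 1 and the 4-methoxyphenyl of compound 2, while compound 3 shows that a six-membered aromatic ring of carbon alone does not guarantee it. No measurement offered alongside these numbers speaks to why the groups at this place separate in this way.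

On these data alone, it remains open whether a pyridin-3-yl or furan-2-yl ring at this place would stand with compound 4 or with compound 1, and whether a 4-hydroxyphenyl or 4-(dimethylamino)phenyl group would follow the 4-methoxyphenyl of compound 2. As far as these compounds go, each number also comes from a single concentration in one cell line, so potency and any wider reach of this ranking stay open.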